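Methoxypyridinyl isomer of compound 3: working notes

The source may report more compounds than this note shows. Statements on the series, on what has been measured and on what is new or still open speak of the compounds shown alone.

Measured in an ADME assay (liver) for metabolic stability, with Liver microsome (Rattus norvegicus) as the target, using microsomes and NADPH, with a stated time of 30 min, tested at 1 uM; a lower number here means slower removal, a higher number faster removal of the compound:
- compound 1 `Nc1ccc(S(=O)(=O)N2CCN(c3ncc(C(O)(C(F)(F)F)C(F)(F)F)cc3C#CCCO)CC2)cn1`: 68 mL.min-1.g-1
- compound 2 `CC(C)(C)n1cc(-c2cc(C(O)(C(F)(F)F)C(F)(F)F)cnc2N2CCN(S(=O)(=O)c3ccc(N)nc3)CC2)cn1`: 459 mL.min-1.g-1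
- compound 3 `COc1ccc(-c2cc(C(O)(C(F)(F)F)C(F)(F)F)cnc2N2CCN(S(=O)(=O)c3ccc(N)nc3)CC2)cn1`: 265 mL.min-1.g-1

Compound 3 belongs to the upper pair of these numbers. The pair does not separate, with a 1.7-fold lower number from compound 2 to compound 3 (0.24 log units; within the scatter) as the gap. Against the lowest number the position is clear, with a 3.9-fold higher number from compound 1 to compound 3 (0.59 log units; beyond the scatter) as the distance.

The next compound, compound 4 `COc1cncc(-c2cc(C(O)(C(F)(F)F)C(F)(F)F)cnc2N2CCN(S(=O)(=O)c3ccc(N)nc3)CC2)c1`, has not been measured. The change is 5-methoxypyridin-3-yl in place of 6-methoxypyridin-3-yl on an aromatic carbon and amounts to 5-methoxypyridin-3-yl in place of 6-methoxypyridin-3-yl, on an aromatic carbon ortho to a large group.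

Among the compounds with values here, no measured step moves a methoxy group, so the evidence is indirect. The nearest step exchanges one ring substituent for another, and a 1.7-fold lower number from compound 2 to compound 3 (0.24 log units; within the scatter) stays within the scatter. The larger steps, a 6.8-fold higher number from compound 1 to compound 2 (0.83 log units; beyond the scatter) and a 3.9-fold higher number from compound 1 to compound 3 (0.59 log units; beyond the scatter), both start from the 4-hydroxybut-1-yn-1-yl group and are modest, and they say little about an exchange between two isomers.

No step beyond the scatter is expected in this assay and no direction is favoured. The expected change is a 1.1-fold lower number from compound 3 to compound 4 (0.03 log units; within the scatter) as estimated here. Compound 4 is estimated at 250 mL.min-1.g-1 with an expected range from 125 mL.min-1.g-1 to 480 mL.min-1.g-1 for now.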

Compound 4, intrinsic clearance in microsomes: 58 mL.min-1.g-1
The estimate for compound 4 lay 4.3-fold (0.63 log units) above the measured number; the measured number lies below the stated range.
By their numbers in this assay, from the lowest: compounds 4 and 1 (each within the scatter of the next); then compounds 3 and 2 (each within the scatter of the next).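

In this assay the step from 6-methoxypyridin-3-yl to 5-methoxypyridin-3-yl, on an aromatic carbon ortho to a large group, is beyond the scatter (a 4.6-fold lower number from compound 3 to compound 4 (0.66 log units; beyond the scatter)), so an exchange between two groups with the same atoms and the same counts is enough to separate two compounds at this carbon. The earlier compounds shown here suggested that an aromatic ring here goes with a higher number than 4-hydroxybut-1-yn-1-yl, but compound 4 goes against this: it does not separate from the alkyne (a 1.2-fold lower number from compound 1 to compound 4 (0.07 log units; within the scatter)) and stands clearly apart from the 1-(tert-butyl)-1H-pyrazol-4-yl group (a 7.9-fold lower number from compound 2 to compound 4 (0.90 log units; beyond the scatter)), a group from which the 6-methoxypyridin-3-yl group did not separate. Nothing measured bears on why the two isomers differ in this read-out.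

The compounds shown leave open whether the difference belongs to the methoxy group itself or to the place of the ring nitrogen relative to the shared core. An amine or a nitrile in place of the methoxy group, on either isomeric pyridine, would separate these two readings.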